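The compounds below may be only part of what the source reports. "The series", "measured", "known", "first", "only" and "open" are said of these compounds alone.

Measured so far in a functional assay on CHO cells for antagonist activity at Orexin/Hypocretin receptor type 1 (Homo sapiens), read by FLIPR and calcium flux; a higher number here means a more potent compound, by a factor of ten per unit of this negative logarithm, a lower number a less potent compound:

- compound 1 `Cc1nc(C(=O)N2CCC3(CC3)C[C@H]2CNc2ccc(C(F)(F)F)cn2)c(-c2ccccc2)s1`: 7.7
- compound 2 `Cc1nc(C(=O)N2CC3(CC3)C[C@H]2CNc2cc(C(F)(F)F)ccn2)c(-c2ccccc2)s1`: 8.2
- compound 3 `Cc1ccc(-c2ncccn2)c(C(=O)N2CC3(CC3)C[C@H]2CNc2cc(C(F)(F)F)ccn2)c1`: 7.3

Compound 2 gives the highest of the three numbers in this assay; compound 1 sits nearer to it and compound 3 furthest away, both gaps beyond the usual scatter. Among the measured compounds shown here, compound 1 and compound 3 each differ from compound 2 in more than one place, so no single-point step is known within the measured set, and no step of the kind now proposed has yet been measured.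

Compound 4 `Cc1nc(C(=O)N2CC3(CC3)C[C@H]2CNc2ccc(Cl)cn2)c(-c2ccccc2)s1` is the next compound. It differs from compound 2 in a single place: 5-chloropyridin-2-yl in place of 4-(trifluoromethyl)pyridin-2-yl on an amine nitrogen. The aminopyridine portion is otherwise retained, as is the whole remainder of compound 2.

With nothing measured on this change, expectation rests on compound 2 alone. A small loss in this assay is expected, of a size that may well lie within the scatter, giving a step estimated as a number 0.30 log units lower from compound 2 to compound 4 (within the scatter). Compound 4 is therefore estimated at 7.9, with a likely range from 7.3 to 8.5.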

Compound 4, negative logarithm of the antagonist equilibrium constant: 8.3
Compound 4: the middle estimate sits 0.40 log units below what was measured; the range from low to high includes it.
By their numbers in this assay, from the lowest: compound 3; then compound 1; then compounds 2 and 4 (each within the scatter of the next).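

In this assay, among the compounds shown here, the first single-place step, made on an amine nitrogen, reads a number 0.10 log units higher from compound 2 to compound 4 (within the scatter), so this assay does not separate 5-chloropyridin-2-yl from 4-(trifluoromethyl)pyridin-2-yl. The position therefore accepts a change in both the substituent and its place on the pyridine, and a group with fewer heavy atoms in place of the one it replaces, without a shift beyond the scatter. Nothing on hand offers an explanation for this result.

With the substituent and its ring place changing together, their separate contributions remain unresolved, and 4-chloropyridin-2-yl or an unsubstituted pyridin-2-yl would bear directly on that. A single step also leaves open whether the same exchange would read alike with the other amide portion of compound 3.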